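Adding a second chloro to the shared core: compound 4

A few compounds are considered here, and "the series" means these few. Any claim that something is new, unique, unknown or untested is made for them only; others in the source may bear on it.

Measured so far:
compound 1 `ClCc1ccccc1Cn1cnc2c(Cl)nc(Cl)nc21` – in a functional assay on SK-MEL-28 cells (Homo sapiens) for cytotoxicity, read by sulforhodamine B assay, with a stated time of 48 h (on this read-out higher numbers stand for lower toxicity in this test and lower numbers for higher toxicity in this test), compound 1 gives "not determined" (no result reported)
compound 2 `ClCc1cccc(Cn2cnc3ncnc(Cl)c32)c1` – 42700 nM
compound 3 `ClCc1cccc(Cn2cnc3c(Cl)ncnc32)c1` – 28800 nM

Among the measured compounds shown here, compound 3 is one of only two compounds with a number in this assay; the value of compound 2 lies within the usual scatter of it, so no order between the two is claimed, and compound 1 adds nothing here.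

Compound 4 `ClCc1cccc(Cn2cnc3c(Cl)nc(Cl)nc32)c1` differs from compound 3 by chloro in place of hydrogen on an aromatic carbon. For the measured compounds named here, no measured pair shows such a change, so the size of the step is not known from data. The expectation is a small step, if any, from compound 3 to compound 4, a 1.4-fold lower number from compound 3 to compound 4 (0.16 log units; within the scatter), with a slight lean toward a lower number. Compound 4 is estimated at 20000 nM, within 8000 nM to 60000 nM.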

Compound 4, concentration lethal to 50% of the cells: > 100000 nM
Compound 4 ended at the assay's limit (the forecaster's own chance of this, stated with the estimate: 10%); middle value at least 5.0-fold (0.69 log units) from the limit.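

In this assay, among the compounds shown here, chloro in place of hydrogen on an aromatic carbon, between two ring nitrogen atoms, gives an at least 3.4-fold higher number from compound 3 to compound 4 (0.54 log units; beyond the scatter), the only step so far. This position therefore responds to a single added chloro, and the response runs toward a higher number, which here means lower toxicity in this test. Compound 4 sits at a limit of the assay, so the true size of the step stays unknown: the limit of > 100000 nM in this assay, at which 1 of the 4 values shown sits.

Going by these compounds, whether this step is specific to chloro remains open. An amine or a methoxy group at this position could show whether other groups move the number the same way.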